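Swapping 4-methoxyphenyl for 1-acetylpiperidin-4-yl

The source may hold more compounds than are shown below. What is called first, only, known or untested is meant among the compounds shown, and "the series" means these compounds.

- compound 1 `COc1ncc(-c2ccc3ncc(NCC4CCCCC4)c(OC)c3c2)cc1NS(=O)(=O)c1ccc(F)cc1F` – 9000 nM
- compound 2 `CCNc1cnc2ccc(-c3cnc(OC)c(NS(=O)(=O)c4ccc(F)cc4F)c3)cc2c1OC` – 4820 nM
- compound 3 `COc1ccc(CNc2cnc3ccc(-c4cnc(OC)c(NS(=O)(=O)c5ccc(F)cc5F)c4)cc3c2OC)cc1` – 4520 nM

All three values come from a functional assay on PC-3 cells (Homo sapiens) for antiproliferative activity, read by sulforhodamine B assay, with a stated time of 72 h; on this read-out lower numbers stand for stronger inhibition and higher numbers for weaker inhibition. Compound 3, at 4520 nM, cannot be separated from the other two: the data show a 1.1-fold lower number from compound 2 to compound 3 (0.03 log units; within the scatter) and a 2.0-fold lower number from compound 1 to compound 3 (0.30 log units; within the scatter).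

Compound 4 `COc1ncc(-c2ccc3ncc(NCC4CCN(C(C)=O)CC4)c(OC)c3c2)cc1NS(=O)(=O)c1ccc(F)cc1F` differs from compound 3 in one place: 1-acetylpiperidin-4-yl stands in place of 4-methoxyphenyl on a saturated chain carbon bound to a nitrogen on an aromatic ring. The counted difference reads (1-acetylpiperidin-4-yl in place of 4-methoxyphenyl on a saturated chain carbon bound to a nitrogen on an aromatic ring).

Among the compounds with values here, no measured compound carries the entering group, so the estimate rests on the steps at this same place. Besides the two above, the data show a 1.9-fold lower number from compound 1 to compound 2 (0.27 log units; within the scatter). The step closest to the one at hand is a 2.0-fold lower number from compound 1 to compound 3 (0.30 log units; within the scatter), since it also joins 4-methoxyphenyl to a non-aromatic ring, cyclohexyl. None of the three steps leaves the scatter, so no step beyond the scatter is expected here, in either direction. The step expected in this assay is a 1.3-fold higher number from compound 3 to compound 4 (0.12 log units; within the scatter). For compound 4 the estimated value is 6000 nM, with an expected range from 2500 nM to 14000 nM.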

Compound 4, half-maximal inhibitory concentration: 2570 nM
Compound 4: the middle estimate sits 2.3-fold (0.37 log units) above what was measured; the range from low to high includes it.
By their numbers in this assay, from the lowest: compounds 4, 3, 2 and 1 (each within the scatter of the next, the first and the last beyond it).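

In this assay, within the data shown here, the earlier compounds gave no step beyond the scatter at this position, but the 1-acetylpiperidin-4-yl group now gives one, a 3.5-fold lower number from compound 1 to compound 4 (0.54 log units; beyond the scatter), a modest change from cyclohexyl. The steps from the other two groups stay within the scatter, with a 1.8-fold lower number from compound 3 to compound 4 (0.25 log units; within the scatter) for the change from 4-methoxyphenyl and a 1.9-fold lower number from compound 2 to compound 4 (0.27 log units; within the scatter) for the change from methyl. Among these compounds, a six-membered non-aromatic ring at this place therefore does not settle the value by itself, since compound 1 and compound 4 both carry one and yet are the only pair of the four separated beyond the scatter, and no measurement at hand offers an explanation for this difference.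

The compounds shown leave open whether the difference between cyclohexyl and 1-acetylpiperidin-4-yl follows the ring nitrogen or the acetyl group, a question that piperidin-4-yl without the acetyl group or a tetrahydropyran-4-yl ring would address. They also leave open how this position would respond to a carboxylic acid or to a longer chain ending in a dimethylamino group.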